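Chloro at the shared core: compound 1 to compound 3

The source may hold more compounds than are shown below. What is called first, only, known or untested is meant among the compounds shown, and "the series" means these compounds.

Measured so far:
compound 1 `CN(C)CC[C@H](CSc1ccccc1)Nc1ccc(S(=O)(=O)Nc2ncnc3c2CCN(C2CCN(Cc4ccccc4-c4ccc(Cl)cc4)CC2)C3)cc1S(=O)(=O)C(F)(F)F` — 7 nM
compound 2 `CC(c1ccccc1-c1ccc(Cl)cc1)N1CCC(N2CCc3c(ncnc3NS(=O)(=O)c3ccc(N[C@H](CCN(C)C)CSc4ccccc4)c(S(=O)(=O)C(F)(F)F)c3)C2)CC1` — 2 nM

Within the data shown here, in an assay on isolated protein for binding affinity to Apoptosis regulator Bcl-2 (Homo sapiens), read by surface plasmon resonance (a higher number here means weaker binding, a lower number tighter binding), compound 1 gives 7 nM, the higher of the two numbers; the only neighbour is compound 2 at 2 nM, reached by a 3.5-fold lower number from compound 1 to compound 2 (0.54 log units; beyond the scatter). Compound 3 `CN(C)CC[C@H](CSc1ccccc1)Nc1ccc(S(=O)(=O)Nc2nc(Cl)nc3c2CCN(C2CCN(Cc4ccccc4-c4ccc(Cl)cc4)CC2)C3)cc1S(=O)(=O)C(F)(F)F` differs from compound 1 by chloro in place of hydrogen on an aromatic carbon. Among the measured compounds shown here, no measured step touches this aromatic carbon of the shared core, so the one known step gives no direct guide; it shows only that a single small change here can move the number modestly. For compound 3 the expectation is therefore no change at the digits printed from compound 1 to compound 3 (within the scatter), an estimated 7 nM within 2.5 nM to 20 nM.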

Compound 3, dissociation constant: 17 nM
The estimate for compound 3 lay 2.4-fold (0.39 log units) below the measured number; measured number inside the range.
By their numbers in this assay, from the lowest: compound 2; then compound 1; then compound 3.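

Read in this assay, chloro in place of hydrogen gives a 2.4-fold higher number from compound 1 to compound 3 (0.39 log units; beyond the scatter) at this aromatic carbon between two ring nitrogen atoms. This position of the shared core therefore responds to a single added chlorine atom, and the change runs toward weaker binding. No evidence at hand accounts for the shift.

Going by these compounds, whether a methyl, a methoxy or an amine at this carbon would move the number as chloro does stays open. Also open, on these data alone, is whether chloro here has the same effect on the methyl-bearing compound 2.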